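Swapping a cyclopentenyl ring for a hydroxyethylamino chain

A few compounds are considered here, and "the series" means these few. Any claim that something is new, unique, unknown or untested is made for them only; others in the source may bear on it.

Among the compounds with values here, in an assay on HEK293 cells for antagonist activity at P2X purinoceptor 7 (Homo sapiens), read by fluorescence, with stated times of 20 min and 30 min (a higher number here means a weaker inhibitor, a lower number a stronger inhibitor), compound 3 `O=C(NCC1CCC(F)(F)CC1)c1c(Cl)ccc2nc(C3=CCCC3)ccc12` gives 36 nM, which places it second highest of the three numbers measured so far. Compound 2 `COCCOc1ccc2c(C(=O)NCC3CCC(F)(F)CC3)c(Cl)ccc2n1` gives 25 nM, and the step of a 1.4-fold higher number from compound 2 to compound 3 (0.16 log units; within the scatter) lies within the scatter. Compound 1 `COCCNc1ccc2c(C(=O)NCC3CCC(F)(F)CC3)c(Cl)ccc2n1` gives 89 nM, and the step of a 2.5-fold lower number from compound 1 to compound 3 (0.39 log units; beyond the scatter) is modest. Compound 4 `O=C(NCC1CCC(F)(F)CC1)c1c(Cl)ccc2nc(NCCO)ccc12` differs from compound 3 in one place: (2-hydroxyethyl)amino in place of cyclopent-1-en-1-yl on an aromatic carbon. The most telling comparison is the step between compound 1 and compound 3 run backwards, since the (2-methoxyethyl)amino group of compound 1 and the entering (2-hydroxyethyl)amino group are both amino-linked chains rather than rings. A modest rise in this assay is therefore expected, a 2.8-fold higher number from compound 3 to compound 4 (0.44 log units; beyond the scatter). Compound 4 is estimated at 100 nM, with an expected range from 40 nM to 250 nM.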

Compound 4, half-maximal inhibitory concentration: 72 nM
The estimate for compound 4 lay 1.4-fold (0.14 log units) above the measured number; measured number inside the range.
By their numbers in this assay, from the lowest: compounds 2, 3, 4 and 1 (each within the scatter of the next, the first and the last beyond it).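

In this assay, the (2-hydroxyethyl)amino chain next to the ring nitrogen cannot be told apart from the cyclopent-1-en-1-yl ring (a 2.0-fold higher number from compound 3 to compound 4 (0.30 log units; within the scatter)). Hydrogen in place of methyl on the chain's oxygen also makes no clear difference (a 1.2-fold lower number from compound 1 to compound 4 (0.09 log units; within the scatter)). Only the oxygen-linked 2-methoxyethoxy chain of compound 2 stands modestly apart (a 2.9-fold higher number from compound 2 to compound 4 (0.46 log units; beyond the scatter)).

From the compounds shown here alone, whether a longer chain such as (3-hydroxypropyl)amino or a saturated cyclopentyl ring would fit this pattern remains open. No evidence here explains these numbers.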